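A few compounds are considered here, and "the series" means these few. Any claim that something is new, unique, unknown or untested is made for them only; others in the source may bear on it.

Values in an ADME assay on HEK293 cells (Homo sapiens) for cytotoxicity, read by MTT assay, with a stated time of 24 h (a lower number here means a stronger inhibitor, a higher number a weaker inhibitor), so far:
compound 1 `CN1CCN(c2nc3cc([N+](=O)[O-])ccc3nc2NCc2ccc(C(F)(F)F)cc2)CC1` gives 6.99 ug/mL as measured
compound 2 `CN(C)CCCNc1nc2cc([N+](=O)[O-])ccc2nc1NCc1ccc(Cl)cc1` gives 10.7 ug/mL as measured

Among the compounds with values here, compound 2 stands within the scatter of compound 1, and no measured pair yet differs in one place only. Compound 3 `CN(C)CCCNc1nc2cc([N+](=O)[O-])ccc2nc1NCc1ccccc1Br` follows from compound 2 through one change: 2-bromophenyl in place of 4-chlorophenyl on a saturated chain carbon bound to a nitrogen on an aromatic ring. In this assay no shift beyond the scatter is expected. The estimated step of a 1.2-fold lower number from compound 2 to compound 3 (0.08 log units; within the scatter) is expected to stay that small. Compound 3 is estimated at 9 ug/mL with an expected range from 4 ug/mL to 20 ug/mL once measured.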

Compound 3, half-maximal inhibitory concentration: 51.9 ug/mL
Estimate against measurement, compound 3: 5.8-fold (0.76 log units) below; measured number above the stated range.
By their numbers in this assay, from the lowest: compounds 1 and 2 (each within the scatter of the next); then compound 3.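

In this assay, the aryl group on a saturated chain carbon bound to a nitrogen on an aromatic ring proves able to move the number beyond the scatter, with 2-bromophenyl in place of 4-chlorophenyl giving a 4.9-fold higher number from compound 2 to compound 3 (0.69 log units; beyond the scatter). Within the data shown here, this is the first one-place comparison, and the side chain and core stay the same across it. Nothing measured here accounts for the step.

The change swaps the halogen and its ring position together, so the step cannot be assigned to either one. A 4-bromophenyl or 2-chlorophenyl group at this place would separate the two.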